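The source may report more compounds than this note shows. Statements on the series, on what has been measured and on what is new or still open speak of the compounds shown alone.

Measured so far in a functional assay on HCT-116 cells (Homo sapiens) for inhibition (a higher number here means a weaker inhibitor, a lower number a stronger inhibitor), are two compounds:
compound 1 `CC(=O)Oc1ccc(/C=C/c2ccc3ccccc3c2)cc1` gives > 5000 nM
compound 2 `FC(F)(F)Oc1cccc(/C=C\c2ccc3ccccc3c2)c1` gives 3500 nM

Compound 1 has a reading of > 5000 nM, which is a limit of the assay and not a number. Compound 3 `FC(F)(F)c1ccc(/C=C/c2ccc3ccccc3c2)cc1` departs from compound 1 in one place, (trifluoromethyl in place of acetoxy on an aromatic carbon), which puts trifluoromethyl in place of acetoxy on an aromatic carbon, para to a large group. Among the compounds with values here, no measured step between compounds differing in one place is available as a guide. Within the data shown here, the only actual number is that of compound 2 at 3500 nM in this assay, and it sets the scale of the expectation. The expected change is the estimated step of an at least 1.2-fold lower number from compound 1 to compound 3 (0.09 log units; that floor lies within the scatter) in this assay, with none beyond the scatter foreseen, and another limit is quite possible. For compound 3 the expected value of 4000 nM carries an estimated range from 1500 nM to 10000 nM as its spread.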

Compound 3, half-maximal inhibitory concentration: > 5000 nM
Compound 3: only a limit was reported; the forecaster's own chance of this, stated with the estimate: 45%; middle value at least 1.2-fold (0.09 log units) away from the limit.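

In this assay compound 3 gives > 5000 nM, a limit of the assay and not a number. Within the data shown here, compound 1 also stands at a limit, so no step between compound 1 and compound 3 can be read. From the compounds shown here alone, whether trifluoromethyl in place of acetoxy changes inhibition at all, and in which direction, stays open.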